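Replacing a methyl with hydroxy in a cinnamanilide series

The compounds below may be only part of what the source reports. "The series", "measured", "known", "first", "only" and "open" are said of these compounds alone.

Three measured compounds set the scene. In a functional assay on CHO cells for inhibition of transient receptor potential cation channel subfamily V member 1 (Homo sapiens) (on this read-out lower numbers stand for stronger inhibition and higher numbers for weaker inhibition), compound 1 `CC(C)C/C(=C\C(=O)Nc1ccc2c(c1)OCCO2)c1ccc(C(C)(C)C)cc1` gives 94 nM and compound 2 `CC(C)(C)c1ccc(/C=C/C(=O)Nc2ccc3c(c2)OCCN3)cc1` gives 57 nM. Compound 3 `Cc1ccc(/C=C/C(=O)Nc2ccc3c(c2)OCCO3)cc1` stands apart: in this assay compound 3 gives 1100 nM, the highest number of the three, with compound 1 and compound 2 both lower by gaps that lie beyond the scatter. Compound 4 `O=C(/C=C/c1ccc(O)cc1)Nc1ccc2c(c1)OCCO2` has not yet been measured. It differs from compound 3 by hydroxy in place of methyl on an aromatic carbon. For the measured compounds named here, no measured pair shows this change, so any expectation rests on the weak position of compound 3 alone. The step of a 2.7-fold higher number from compound 3 to compound 4 (0.44 log units; beyond the scatter) is expected to run toward a higher number. For compound 4 the estimate is 3000 nM, within a range of 800 nM to 12000 nM.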

Compound 4, half-maximal inhibitory concentration: > 4000 nM
Compound 4 ended at the assay's limit; the forecaster's own chance of this, stated with the estimate: 15%; at least 1.3-fold (0.12 log units) between middle value and limit.
By their numbers in this assay, from the lowest: compounds 2 and 1 (each within the scatter of the next); then compound 3. At a limit, above all of these: compound 4.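

In this assay compound 4 gives > 4000 nM, which is a limit of the assay and not a number. For the compounds shown here, this gives the first single-place step in the set: hydroxy in place of methyl, para to a large group, produces an at least 3.6-fold higher number from compound 3 to compound 4 (0.56 log units; beyond the scatter), so this position still responds to change even on an already weak compound. How far the step reaches cannot be read from a limit: the limit of > 4000 nM in this assay, at which 1 of the 4 values shown sits.

On these data alone, whether an amine or a methoxy group here would behave like methyl or like hydroxy stays open. So does the effect of the same change on the core of compound 2.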